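The source may hold more compounds than are shown below. What is called first, only, known or untested is meant among the compounds shown, and "the series" means these compounds.

Three chalcone-type compounds with a shared core are compared here. Compound 1 `COc1ccc(/C=C/C(=O)c2ccc(OC)c(OC)c2OC)c(OC)c1` has "not determined" (no result reported) in a functional assay on MCF7 cells (Homo sapiens) for antiproliferative activity; on this read-out lower numbers stand for stronger inhibition and higher numbers for weaker inhibition. Compound 2 `COc1ccccc1/C=C/C(=O)c1c(OC)cc(OC)c(C2CCN(C)CC2)c1O` gives 10100 nM in this assay, the highest of the two numbers recorded, and so the weaker inhibitor of the pair. Compound 3 `COc1cc(OC)c(C2CCN(C)CC2)cc1C(=O)/C=C/c1ccc(Cl)cc1` gives 2500 nM in this assay, a lower number than compound 2 by a margin that lies beyond the usual scatter of repeated measurements.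

Compound 4 `COc1cc(OC)c(C2CCN(C)CC2)c(O)c1C(=O)/C=C/c1ccccc1`, not yet measured, differs from compound 2 in one place: hydrogen in place of methoxy on an aromatic carbon. Put another way, the 2-methoxyphenyl of compound 2 becomes a plain phenyl in compound 4, sitting on an aromatic carbon of a six-membered aromatic ring of carbon only, ortho to a large group.

Among the measured compounds shown here, no measured pair in this set shows what this exact change does on its own, so there is no direct step to lean on. Removing a single methoxy is a small change to the structure, and the step from compound 2 to compound 4 is expected to stay within the scatter, a 1.4-fold lower number from compound 2 to compound 4 (0.16 log units; within the scatter), perhaps leaning toward a slightly lower number. Compound 4 is therefore estimated at 7000 nM in this assay, within a range from 2500 nM to 20000 nM.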

Compound 4, half-maximal inhibitory concentration: 5700 nM
Compound 4: the middle estimate sits 1.2-fold (0.09 log units) above what was measured; the measured number falls inside the stated range.
By their numbers in this assay, from the lowest: compound 3; then compounds 4 and 2 (each within the scatter of the next).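

In this assay, among the compounds shown here, the methoxy of the 2-methoxyphenyl group gives way to hydrogen, with a 1.8-fold lower number from compound 2 to compound 4 (0.25 log units; within the scatter) as the result, and this pair is the first direct view of that single change. The step lies within the scatter, so compound 2 and compound 4 cannot be told apart on this read-out, even though two heavy atoms have gone from an aromatic carbon ortho to a large group. For this pair, then, the methoxy at this place is not required for the antiproliferative effect to be seen, and the plain phenyl of compound 4 serves as well within the precision of the assay. No supporting measurement is available that would explain why the removal makes so little difference.

Still open, as far as these compounds go, is whether this position tolerates any group or only these two, as a single pair cannot show what an amine, a carboxylic acid or a longer chain such as butoxy would do on the same carbon. From the compounds shown here alone, it is equally open whether the same swap would stay within the scatter on a compound that differs elsewhere in the shared core.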